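The source may report more compounds than this note shows. Statements on the series, on what has been measured and on what is new or still open speak of the compounds shown alone.

Measured so far:
Compound 1 `COc1cccc(NC(=S)NCCNS(=O)(=O)c2ccc(-c3ccccc3Oc3ccc([N+](=O)[O-])cc3)s2)c1` — in an ADME assay on HEK-293T cells (Homo sapiens) for cytotoxicity, read by CCK-8 assay, with a stated time of 48 h (on this read-out lower numbers stand for stronger inhibition and higher numbers for weaker inhibition), compound 1 gives only a limit, > 20000 nM.
Compound 2 `O=[N+]([O-])c1ccc(Oc2ccccc2-c2ccc(S(=O)(=O)NCCNC(=S)Nc3cccc(Cl)c3)s2)cc1` — in this assay compound 2 gives 4990 nM.
Compound 3 `O=C(NCCNS(=O)(=O)c1ccc(-c2ccccc2Oc2ccc([N+](=O)[O-])c([N+](=O)[O-])c2)s1)Nc1ccc(Cl)cc1` — in this assay compound 3 gives only a limit, > 20000 nM.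

Among the measured compounds shown here, the one counted step runs from compound 2 to compound 1: methoxy in place of chloro on an aromatic carbon, giving an at least 4.0-fold higher number from compound 2 to compound 1 (0.60 log units; beyond the scatter). How the core of compound 3 differs from that of compound 2 is not broken down here. Compound 4 `COc1ccc(NC(=O)NCCNS(=O)(=O)c2ccc(-c3ccccc3Oc3ccc([N+](=O)[O-])c([N+](=O)[O-])c3)s2)cc1` is compound 3 with methoxy in place of chloro on an aromatic carbon; the place is para to a large group where in compound 1 it is meta to a large group, so this is the same kind of change, not the same. Since compound 3 already sits at the limit of > 20000 nM in this assay, at which 2 of the 3 values shown sit, compound 4 is expected to stay there, an expected step that the limit leaves unreadable from compound 3 to compound 4. For compound 4 the estimate in this assay is 30000 nM, between 15000 nM and 80000 nM.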

Compound 4, half-maximal inhibitory concentration: 18500 nM
Compound 4: the middle estimate sits 1.6-fold (0.21 log units) above what was measured, within the range that was stated.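

In this assay, methoxy in place of chloro does not act as one fixed step on the two cores: the same change on two cores in this assay, an at least 4.0-fold higher number (0.60 log units; beyond the scatter) from compound 2 to compound 1 and an at least 1.0-fold lower number (0.03 log units; that floor lies within the scatter) from compound 3 to compound 4, at least 4.3-fold (0.63 log units) apart, beyond the scatter of two such steps. Compound 3 gives > 20000 nM, which is a limit and not a number, so an at least 1.0-fold lower number from compound 3 to compound 4 (0.03 log units; that floor lies within the scatter) gives only a floor and leaves the true size of the step on this core unknown. No rule for carrying the change across the series follows, and the place of the change also differs between the two pairs.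

Open, from the compounds shown here alone, is what an amine or a carboxylic acid at the place of the chloro would give in this assay. Also open is the true size of the steps that touch the limit: the limit of > 20000 nM in this assay, at which 2 of the 4 values shown sit.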